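The source may report more compounds than this note shows. Statements on the series, on what has been measured and on what is new or still open speak of the compounds shown alone.

In a functional assay on ECa-109 cells (Homo sapiens) for inhibition, read by MTT assay, with a stated time of 72 h (on this read-out lower numbers stand for stronger inhibition and higher numbers for weaker inhibition), compound 1 `N#Cc1c(Nc2cccc(Cl)c2)nc(SCc2cn(Cc3ccccc3Cl)nn2)nc1-c1ccccc1` gives 24400 nM and compound 2 `Cc1cccc(Nc2nc(SCc3cn(Cc4ccccc4Cl)nn3)nc(-c3ccccc3)c2C#N)c1` gives 15600 nM; the change between them, (methyl in place of chloro on an aromatic carbon), makes a step of a 1.6-fold lower number from compound 1 to compound 2 (0.19 log units; within the scatter). Compound 3 `Cc1ccccc1Nc1nc(SCc2cn(Cc3ccc(Cl)cc3)nn2)nc(-c2ccccc2)c1C#N` is known in this assay only as a limit, > 64000 nM. How the core of compound 3 differs from the core of compound 1 is not broken down here. Compound 4 `Cc1ccc(Cn2cc(CSc3nc(Nc4ccccc4C)c(C#N)c(-c4ccccc4)n3)nn2)cc1` has not been measured; it differs from compound 3 by methyl in place of chloro on an aromatic carbon, the same kind of change as from compound 1 to compound 2, although there the group sits meta to a large group and here para to a large group. Since that earlier step of a 1.6-fold lower number from compound 1 to compound 2 (0.19 log units; within the scatter) stayed within the scatter, the step for compound 4 is expected to be a step that the limit leaves unreadable from compound 3 to compound 4. Compound 4 is therefore estimated at 80000 nM, most likely reported again only as a limit.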

Compound 4, half-maximal inhibitory concentration: > 64000 nM
Compound 4: only a limit was reported; the forecaster's own chance of this, stated with the estimate: 65%; the middle value lies beyond the limit too.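

In this assay, for the compounds shown here, compound 4 gives only a limit, > 64000 nM, as compound 3 does, so no step between compound 3 and compound 4 can be read. The compounds shown leave open whether 4-chlorobenzyl to 4-methylbenzyl changes inhibition at all.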